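Aryl group exchanges on a nitrogen of a shared core

This account rests on a few compounds, and the source may have more. Where it says the series, first, only, none or still open, it means among the compounds named here.

Three measured compounds share one core and differ only in the aryl group on a nitrogen on an aromatic ring. In a functional assay on A549 cells (Homo sapiens) for antiproliferative activity, read by MTT assay, with a stated time of 72 h (on this read-out higher numbers stand for weaker inhibition and lower numbers for stronger inhibition), compound 1 `COc1cc2ncnc(Nc3ccc(Cl)c(C(F)(F)F)c3)c2cc1OCCCCC(=O)Nc1ccc(S(N)(=O)=O)cc1` gives 9270 nM. Compound 2 `C#Cc1cccc(Nc2ncnc3cc(OC)c(OCCCCC(=O)Nc4ccc(S(N)(=O)=O)cc4)cc23)c1` gives 7720 nM in this assay. Compound 3 `COc1cc2ncnc(Nc3cccc(Br)c3)c2cc1OCCCCC(=O)Nc1ccc(S(N)(=O)=O)cc1` gives 14900 nM in this assay, the highest of the three numbers, though its steps to the other two stay within the scatter: a 1.6-fold higher number from compound 1 to compound 3 (0.21 log units; within the scatter) and a 1.9-fold higher number from compound 2 to compound 3 (0.29 log units; within the scatter). The remaining step, a 1.2-fold lower number from compound 1 to compound 2 (0.08 log units; within the scatter), is likewise within the scatter.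

Compound 4 `COc1cc2ncnc(Nc3ccc(Br)cc3)c2cc1OCCCCC(=O)Nc1ccc(S(N)(=O)=O)cc1` is not yet measured. Its difference from compound 3 is 4-bromophenyl in place of 3-bromophenyl on a nitrogen on an aromatic ring. Within the data shown here, no measured step moves a bromine to another position of the same ring; the three measured steps each exchange the whole aryl group, and none of them leaves the scatter. On that basis no step beyond the scatter is expected in this assay, and the step is estimated as a 1.1-fold lower number from compound 3 to compound 4 (0.03 log units; within the scatter). Compound 4 is therefore expected to give about 14000 nM in this assay, with a range from 5000 nM to 40000 nM.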

Compound 4, half-maximal inhibitory concentration: > 40000 nM
Compound 4 gave a limit, no number; the forecaster's own chance of this, stated with the estimate: 10%; middle value at least 2.8-fold (0.45 log units) away from the limit.
By their numbers in this assay, from the lowest: compounds 2, 1 and 3 (each within the scatter of the next). At a limit, above all of these: compound 4.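

In this assay, among these compounds, moving the bromine from 3-bromophenyl to 4-bromophenyl on this nitrogen gives an at least 2.6-fold higher number from compound 3 to compound 4 (0.42 log units; beyond the scatter), so an exchange of the same atoms, joined differently, leaves the scatter, which no step among compound 1, compound 2 and compound 3 did. The two whole-group exchanges ending at 4-bromophenyl also leave it, with an at least 5.1-fold higher number from compound 2 to compound 4 (0.71 log units; beyond the scatter) and an at least 4.3-fold higher number from compound 1 to compound 4 (0.63 log units; beyond the scatter). The reading for compound 4 is a limit, not a number: the limit of > 40000 nM in this assay, at which 1 of the 4 values shown sits.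

Compound 1 carries 4-chloro-3-(trifluoromethyl)phenyl and stays within the scatter of compound 2 and compound 3, which goes against any general rule for groups named at 4 on this ring. As far as these compounds go, how 4-chlorophenyl, or an amine or a carboxylic acid in place of the bromine, would read remains open.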